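This account rests on a few compounds, and the source may have more. Where it says the series, first, only, none or still open, it means among the compounds named here.

Measured so far:
compound 1 `CCOC(=O)c1cncc(-c2ccc(OCC)cc2)c1` gives 130000 nM in an assay on COS-7 cells for inhibition of patatin-like phospholipase domain-containing protein 2 (Mus musculus); on this read-out lower numbers stand for stronger inhibition and higher numbers for weaker inhibition;
compound 2 `CCOC(=O)c1cccc(-c2ccc(CN3CCN(C)CC3)o2)c1` gives 120000 nM in this assay;
compound 3 `CCOc1ccc(-c2cccc(S(=O)(=O)NC)c2)cc1` gives 200000 nM in this assay.

Compound 3 has the highest of the three numbers, yet both other compounds lie within the usual scatter of it, so no ordering among the three can be claimed; all three sit at the weak end of this assay. The untested compound 4 `CCOc1ccc(-c2cccc(NC(=O)N(C)C)c2)cc1` differs from compound 3 in one place: (dimethylcarbamoyl)amino in place of methylsulfamoyl on an aromatic carbon. For the measured compounds named here, no measured pair shows the effect of such a change, so the expectation rests on the three weak numbers alone. The expected step is a 1.3-fold lower number from compound 3 to compound 4 (0.12 log units; within the scatter), which is none beyond the scatter in either direction. Compound 4 is estimated at 150000 nM, with a range from 50000 nM to 450000 nM.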

Compound 4, half-maximal inhibitory concentration: 70000 nM
The estimate for compound 4 lay 2.1-fold (0.33 log units) above the measured number; the range from low to high includes it.
By their numbers in this assay, from the lowest: compounds 4, 2, 1 and 3 (each within the scatter of the next, the first and the last beyond it).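

For the compounds shown here, putting (dimethylcarbamoyl)amino in place of methylsulfamoyl on this aromatic carbon gives a 2.9-fold lower number from compound 3 to compound 4 (0.46 log units; beyond the scatter) in this assay, and this is the only single-place change available here. It shows that the number responds to the group at this position, although the step is modest. Nothing measured here explains the shift.

On these data alone, whether a primary amine, a carboxylic acid or a longer urea chain at this position would lower the number further remains open. Also open, as far as these compounds go, is whether the same change would give a similar step on another core.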